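Aryl swap on the triazole of a diterpenoid scaffold

This account rests on a few compounds, and the source may have more. Where it says the series, first, only, none or still open, it means among the compounds named here.

Measured so far:
- Compound 1, `C=C1CC[C@@H](C(C)C)[C@]12CC=C(C=O)CC2`: 165000 nM
- Compound 2, `C=C1CCC[C@]2(C)CCC(c3cn(-c4ccc(OC)cc4)nn3)=CC[C@@]12C`: 58900 nM

Two compounds have numbers in a functional assay on DU-145 cells (Homo sapiens) for cytotoxicity, read by MTT assay, with a stated time of 48 h; on this read-out lower numbers stand for stronger inhibition and higher numbers for weaker inhibition. Compound 1 gives 165000 nM. Compound 2, which carries a triazole bearing a 4-methoxyphenyl on its aromatic nitrogen, gives 58900 nM in this assay; that is the lowest of the two numbers, and the gap to compound 1 is beyond the usual scatter, so compound 2 is the stronger of the pair.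

Compound 3, `C=C1CCC[C@]2(C)CCC(c3cn(-c4cccc([N+](=O)[O-])c4)nn3)=CC[C@@]12C`, is not yet measured. It differs from compound 2 in one place: 3-nitrophenyl in place of 4-methoxyphenyl on an aromatic nitrogen. The rest of the structure is kept.

Going by the values given here, no measured pair shows what such a change on the aromatic nitrogen does here, so the direction of the step is open. With only the aryl group on the triazole exchanged, the step of a 1.3-fold lower number from compound 2 to compound 3 (0.12 log units; within the scatter) is expected to stay small, likely no larger than the scatter, in either direction. Compound 3 is therefore estimated at 45000 nM in this assay, with a range from 15000 nM to 150000 nM.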

Compound 3, half-maximal inhibitory concentration: 62500 nM
Compound 3: the middle estimate sits 1.4-fold (0.14 log units) below what was measured; the range from low to high includes it.
By their numbers in this assay, from the lowest: compounds 2 and 3 (each within the scatter of the next); then compound 1.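

In this assay, going by these compounds alone, putting 3-nitrophenyl in place of 4-methoxyphenyl on the aromatic nitrogen of the triazole gives a 1.1-fold higher number from compound 2 to compound 3 (0.03 log units; within the scatter), so this is the first direct reading of a change at this position, and the two compounds cannot be told apart. For this one pair, a quite different aryl group on that nitrogen, one that also enters with an extra hydrogen-bond acceptor, leaves the cytotoxicity reading where it was, although one swap is too little to call the position insensitive in general. No supporting measurement is available that could explain why the two aryl groups read alike.

This swap alters both the substituent and its place on the phenyl ring, so 4-nitrophenyl or 3-methoxyphenyl would be needed to separate the two changes, and either effect could be hidden if the two happened to offset each other. On these data alone, it also remains open whether a group of another kind on that nitrogen, such as a phenyl ring carrying an amine or a carboxylic acid, or a longer alkyl chain in place of the aryl ring, would move the number beyond the scatter.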